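This account rests on a few compounds, and the source may have more. Where it says the series, first, only, none or still open, it means among the compounds named here.

In a functional assay on NCI-H23 cells (Homo sapiens) for antiproliferative activity, read by sulforhodamine B assay (a lower number here means a stronger inhibitor of growth, a higher number a weaker inhibitor of growth), compound 3 (`O=C(/C=C/c1ccc(O)cc1)c1c(O)cccc1OCC1CCCC1`) gives 3160 nM. Compound 2 (`CC(C)(C)CCOc1cccc(O)c1C(=O)/C=C/c1ccc(O)cc1`) gives 3130 nM, and a 1.0-fold higher number from compound 2 to compound 3 (0.00 log units; within the scatter) places the two level with each other. Compound 1 (`CCCCCCOc1cccc(O)c1C(=O)/C=C/c1ccc(O)cc1`) reaches only a limit of the assay, > 30000 nM.

Compound 4 (`CC(C)CCOc1cccc(O)c1C(=O)/C=C/c1ccc(O)cc1`) differs from compound 3 in one group: isobutyl in place of cyclopentyl on a saturated chain carbon bound to an oxygen on an aromatic ring. Isobutyl stands in place of cyclopentyl on a saturated chain carbon bound to an oxygen on an aromatic ring.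

Going by the values given here, three measured steps bear on this change. Leaving the unbranched chain of compound 1 gives an at least 9.5-fold lower number from compound 1 to compound 2 (0.98 log units; beyond the scatter) and an at least 9.4-fold lower number from compound 1 to compound 3 (0.97 log units; beyond the scatter), both beyond the scatter, and their true size is open since they start from a limit. Exchanging the end group between compound 2 and compound 3 moved nothing, as a 1.0-fold higher number from compound 2 to compound 3 (0.00 log units; within the scatter) shows. Compound 4 keeps a branched chain end, as compound 2 does at 3130 nM, but it has no ring and a shorter end group. The expected result is therefore a small move towards a higher number, a 1.6-fold higher number from compound 3 to compound 4 (0.20 log units; within the scatter). For compound 4 the estimated value is 5000 nM, with an expected range of 2000 nM to 20000 nM.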

Compound 4, concentration for 50% growth inhibition: 12100 nM
The estimate for compound 4 lay 2.4-fold (0.38 log units) below the measured number; the range from low to high includes it.
By their numbers in this assay, from the lowest: compounds 2 and 3 (each within the scatter of the next); then compound 4. At a limit, above all of these: compound 1.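

In this assay, the end groups of the branched chains prove not to be interchangeable, although compounds 2 and 3 had stood level: a 3.8-fold higher number from compound 3 to compound 4 (0.58 log units; beyond the scatter) and a 3.9-fold higher number from compound 2 to compound 4 (0.59 log units; beyond the scatter) are both beyond the scatter. Branching alone therefore does not fix the level at this position, even though the isopentyloxy chain of compound 4 still gives a lower number than the unbranched chain of compound 1, with an at least 2.4-fold lower number from compound 1 to compound 4 (0.39 log units; beyond the scatter). The value of compound 1 is a limit, and so that last step is bounded on one side only: the limit of > 30000 nM in this assay, at which 1 of the 4 values shown sits.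

The compounds shown leave open whether the loss in compound 4 follows the missing ring or the smaller end group. They also leave open how a cyclohexyl or phenyl end group, or an ether oxygen within the chain, would read here.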